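Removing the ring amide acyl in a CXCR3 antagonist pair

This account rests on a few compounds, and the source may have more. Where it says the series, first, only, none or still open, it means among the compounds named here.

Two compounds of the series carry the same bromobenzyl-piperidine arm and have been tested in a functional assay on CHO cells for antagonist activity at C-X-C chemokine receptor type 3 (Homo sapiens), read by GTPgammaS binding, with a stated time of 30 min; a higher number here means a weaker inhibitor, a lower number a stronger inhibitor. Compound 1 `O=C1CCC(c2ccncc2)(C2CCN(Cc3ccc(Br)cc3)CC2)C(=O)N1` gives 630 nM in this assay. Compound 2 `CCC(=O)N1CCCC(c2ccccc2)(C2CCN(Cc3ccc(Br)cc3)CC2)C1` gives 290 nM in this assay, the lowest of the two numbers, and the gap to compound 1 lies beyond the usual scatter.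

Compound 3 `Brc1ccc(CN2CCC(C3(c4ccccc4)CCCNC3)CC2)cc1` has not yet been measured in this assay. It differs from compound 2 in one place: hydrogen in place of propanoyl on an amine nitrogen in a ring. Among the measured compounds shown here, no measured pair of the series shows the same change, so its effect is unknown here. The working expectation is that the step from compound 2 to compound 3 goes towards a higher number, estimated as a 5.2-fold higher number from compound 2 to compound 3 (0.71 log units; beyond the scatter). Compound 3 is accordingly expected to give about 1500 nM in this assay, within a range from 400 nM to 6000 nM.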

Compound 3, half-maximal inhibitory concentration: > 10000 nM
Compound 3 gave a limit, no number; the forecaster's own chance of this, stated with the estimate: 15%; middle value at least 6.6-fold (0.82 log units) away from the limit.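

In this assay compound 3 gives > 10000 nM as a limit of the assay, not a number. On the amine nitrogen of this six-membered ring, the propanoyl group matters for inhibition: putting hydrogen in its place gives an at least 34-fold higher number from compound 2 to compound 3 (1.53 log units; beyond the scatter), a large step and the first read at this position. As far as these compounds go, the full size of the step stays unknown, since the reading stops at the limit: the limit of > 10000 nM in this assay, at which 1 of the 3 values shown sits.

The compounds shown leave open whether activity depends on the carbonyl or only on having a group on that nitrogen; a methyl, an acetyl, a longer acyl chain or a methanesulfonyl group there would separate the two. From the compounds shown here alone, whether the same change carries over to other cores also stays open, as compound 1 differs from compound 2 in more than one place.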